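The source may hold more compounds than are shown below. What is called first, only, known or untested is meant among the compounds shown, and "the series" means these compounds.

Working notes on the series. Compound 1 `Cc1nc(-c2ccsc2)sc1COc1ccc2c(c1)OCC2CC(=O)O` carries a thiophen-3-yl on the shared core, and in a functional assay on CHO cells for agonist activity at Free fatty acid receptor 1 (Homo sapiens), read by FLIPR and calcium flux (on this read-out lower numbers stand for an effect already at smaller amounts and higher numbers for an effect only at larger amounts of compound), compound 1 gives 68.5 nM. Among the compounds with values here, it is the only member with a number: compound 2 `Cc1nc(-c2cc3ccccc3o2)sc1COc1ccc2c(c1)OCC2CC(=O)O` is recorded in this assay as "not determined" (no result reported), and compound 3 `Cc1ccccc1-c1nc(C)c(COc2ccc3c(c2)OCC3CC(=O)O)s1` likewise as "not determined" (no result reported). No comparison between two measured compounds is therefore available in this set. Compound 4 `Cc1cccc(-c2nc(C)c(COc3ccc4c(c3)OCC4CC(=O)O)s2)c1` differs from compound 1 in one place: 3-methylphenyl in place of thiophen-3-yl on an aromatic carbon. With nothing in the series to anchor the effect of 3-methylphenyl in place of thiophen-3-yl, the step is expected to stay close to the scatter, and a 1.4-fold lower number from compound 1 to compound 4 (0.14 log units; within the scatter) is the estimated change, a small move toward effect at smaller amounts at most. Compound 4 is thus expected to give 50 nM in this assay, within 18 nM to 150 nM.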

Compound 4, half-maximal effective concentration: 119 nM
Beside the measured number, compound 4's estimate is 2.4-fold (0.38 log units) below it; the range from low to high includes it.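

In this assay, 3-methylphenyl in place of thiophen-3-yl on this aromatic carbon gives a 1.7-fold higher number from compound 1 to compound 4 (0.24 log units; within the scatter), so the step stays within the scatter. At this position, a six-membered aromatic ring of carbon only therefore stands in for a five-membered aromatic ring with 1 hetero atom without a step beyond the scatter. Nothing further is available on why the two compounds read this way. Steps involving compound 2 and compound 3 cannot be read, and the compounds shown do not separate the methyl of 3-methylphenyl from its ring. From the compounds shown here alone, how a saturated ring such as cyclohexyl or an amine such as piperidin-1-yl would read at this position remains open.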